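Cytotoxicity notes: piperidine to methylpiperazine amide

A few compounds are considered here, and "the series" means these few. Any claim that something is new, unique, unknown or untested is made for them only; others in the source may bear on it.

Measured so far:
compound 1 `CS(=O)(=O)c1ccc(C(=O)NCC(=O)N2CCCCC2)cc1[N+](=O)[O-]` gives 14000 nM
compound 2 `CN(Cc1cccc(F)c1)C(=O)CNC(=O)c1ccc(S(C)(=O)=O)c([N+](=O)[O-])c1` gives a limit, > 27000 nM
compound 3 `CS(=O)(=O)c1ccc(C(=O)N2CCC(C(=O)N3CCN(c4ccccc4)CC3)CC2)cc1[N+](=O)[O-]` gives a limit, > 27000 nM

In an ADME assay on HepG2 cells (Homo sapiens) for cytotoxicity, read by CellTiter-Glo and ATP content, with a stated time of 72 h (a higher number here means that more compound is needed for the effect, a lower number that less compound is needed), compound 1 gives 14000 nM. Among the measured compounds shown here, this is the only number among the three values shown. Compound 2 returns only a limit of the assay, > 27000 nM. Compound 3 likewise returns only a limit, > 27000 nM. For the measured compounds named here, two of the three values therefore sit at the limit of > 27000 nM in this assay, at which 2 of the 3 values shown sit, and compound 1 is the one compound for which a concentration was actually reached within the tested range.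

Compound 4 `CN1CCN(C(=O)CNC(=O)c2ccc(S(C)(=O)=O)c([N+](=O)[O-])c2)CC1` is not yet measured. It differs from compound 1 by 4-methylpiperazin-1-yl in place of piperidin-1-yl on a carbonyl carbon whose other neighbour is a saturated chain carbon. Going by the values given here, no step between measured compounds covers this change, so no measured size can be pointed to. The expectation for this assay is a step from compound 1 to compound 4 of a 1.8-fold higher number from compound 1 to compound 4 (0.25 log units; within the scatter), upward toward the region where compounds 2 and 3 give limits, with a fair chance that compound 4 also reports only a limit. Compound 4 is estimated at 25000 nM, within a range from 10000 nM to 60000 nM.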

Compound 4, half-maximal effective concentration: > 27000 nM
Compound 4 was reported as a limit; the forecaster's own chance of this, stated with the estimate: 50%; middle value at least 1.0-fold (0.03 log units) away from the limit.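

In this assay, among the compounds shown here, the first step at this position is the exchange of piperidin-1-yl for 4-methylpiperazin-1-yl on a carbonyl carbon whose other neighbour is a saturated chain carbon, which gives an at least 1.9-fold higher number from compound 1 to compound 4 (0.28 log units; that floor lies within the scatter). For the compounds shown here, the direction is therefore upward at the least, but the floor of this step lies within the scatter, so the result does not establish a real change between the two amides; it shows only that adding the second ring nitrogen and its methyl group does not bring the number down. The true size of the step cannot be read because compound 4 reports a limit rather than a number, leaving compound 1 as the only compound with a reached concentration: the limit of > 27000 nM in this assay, at which 3 of the 4 values shown sit.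

From the compounds shown here alone, it remains open whether the ring nitrogen or its methyl group accounts for any part of the step, a question that unsubstituted piperazin-1-yl on the same carbonyl carbon would address. Morpholin-4-yl or an open-chain dimethylamino group in this place could show whether a number within the tested range is specific to piperidin-1-yl.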